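A few compounds are considered here, and "the series" means these few. Any claim that something is new, unique, unknown or untested is made for them only; others in the source may bear on it.

Measured so far:
- compound 1, `O=C1CSC(c2cccc(Cl)c2)N1CCN1CCCCC1`: 15%
- compound 2, `COc1ccccc1C1SCC(=O)N1CCN1CCCCC1`: 5%

Both numbers come from an ADME assay on Vero cells (Chlorocebus sabaeus) for cytotoxicity, read by neutral red uptake, tested at 3150 ug/mL; on this read-out higher numbers stand for a weaker effect at the one concentration tested and lower numbers for a stronger effect. Going by the values given here, of the two values shown, the one of compound 1 is the larger, but its distance to compound 2 lies within the scatter of repeated measurements, so the two compounds cannot be told apart on this read-out and no ranking is claimed. Compound 3, `O=C1CSC(c2ccc(Cl)cc2)N1CCN1CCCCC1`, has not yet been measured in this assay. It keeps the core of compound 1 and differs from it in one place: 4-chlorophenyl in place of 3-chlorophenyl on a saturated ring carbon. Among the compounds with values here, no pair of measured compounds that differ in a single place is available, so the size of such a step cannot be read from the data; it is only expected that rearranging the chlorophenyl group on the saturated ring carbon leaves the read-out roughly where compound 1 sits, with no step beyond the scatter. The expected step is no change at the digits printed from compound 1 to compound 3 (within the scatter). For compound 3 the estimate in this assay is 15%, with a range from 3% to 32%.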

Compound 3, a percentage reported as activity, at one concentration (the size of the read-out at that concentration, not a potency): 11%
Estimate against measurement, compound 3: 4 percentage points above; measured number inside the range.
By their numbers in this assay, from the lowest: compounds 2, 3 and 1 (each within the scatter of the next).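

Going by these compounds alone, this pair gives the first step between compounds that differ in one place: in this assay, 4-chlorophenyl in place of 3-chlorophenyl on the saturated ring carbon reads as a number 4 percentage points lower from compound 1 to compound 3 (within the scatter), so the two compounds cannot be told apart. Within the data shown here, for this position, the two chlorophenyl isomers therefore give no distinguishable read-out, a finding that covers only this pair at the one concentration tested. No measurement at hand bears on why the two compounds read alike.

The compounds shown leave open whether the read-out stays in the same place with a 2-chlorophenyl, an unsubstituted phenyl, or a phenyl carrying a carboxylic acid on the saturated ring carbon, since one step between two chlorophenyl isomers says nothing about a change of the group itself. Also open, on these data alone, is how the read-out responds to a change elsewhere on the core of compound 1, for example a dimethylamine or a morpholine within the group of 8 heavy atoms on the ring nitrogen side, or a longer chain in that group.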